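The source may hold more compounds than are shown below. What is called first, only, known or untested is meant among the compounds shown, and "the series" means these compounds.

Among the measured compounds shown here, compound 1 `Cc1nc(-c2ccc(C(F)(F)F)cc2)sc1CNc1ccc(CC(=O)O)cc1` and compound 2 `O=C(CCc1ccc(NCc2cccc(Oc3ccccc3)c2)cc1)N1CCCC1` are the two compounds with numbers so far. In a functional assay on CHO cells for agonist activity at Free fatty acid receptor 1 (Homo sapiens), read by a luciferase reporter (a higher number here means a larger maximal response, a lower number a smaller maximal response), compound 1 gives 18%, the lower of the two values. In this assay compound 2 gives 46%, and the gap between the two lies beyond the usual scatter of this kind of measurement. Compound 3 `Cc1nc(-c2ccc(C(F)(F)F)cc2)sc1CNc1ccc([C@H]2C[C@@H]2C(=O)NC2CCNC2)cc1` has not yet been measured. It differs from compound 1 in one place: 2-((pyrrolidin-3-yl)carbamoyl)cyclopropyl in place of carboxymethyl on an aromatic carbon. For the measured compounds named here, no step between two measured compounds is available to calibrate a change of this kind, so the expectation rests on the two values alone and carries wide uncertainty. A moderate rise in maximal response is expected, a number 10 percentage points higher from compound 1 to compound 3 (within the scatter). For compound 3 in this assay the estimate is 28%, expected to fall between 5% and 60%.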

Compound 3, largest response reached (reported as percent of maximum), in percent of the reference or control that the assay uses: 52%
Compound 3: the middle estimate sits 24 percentage points below what was measured; low and high end bracket the measured number.
By their numbers in this assay, from the lowest: compound 1; then compounds 2 and 3 (each within the scatter of the next).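

At this position, para to a large group, the carboxymethyl of compound 1 is not required for a response in this assay: 2-((pyrrolidin-3-yl)carbamoyl)cyclopropyl takes its place and gives a number 34 percentage points higher from compound 1 to compound 3 (beyond the scatter). The position therefore accepts a far larger group, with 11 heavy atoms instead of 4, a three-membered ring, a five-membered ring and 2 defined stereocentres, and the maximal response still rises. No measurement at hand explains this rise.

The compounds shown do not tell whether the gain belongs to the cyclopropyl ring, the carbamoyl link or the pyrrolidine, as all three enter together in a single step. A carboxylic acid on the same cyclopropyl, an open-chain amine in place of the pyrrolidine, or the opposite configuration at the stereocentres would each bear on that question.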